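A few compounds are considered here, and "the series" means these few. Any claim that something is new, unique, unknown or untested is made for them only; others in the source may bear on it.

Compound 1 `CSc1cnc2ccccc2c1[Se]CC#CCCl`: 0.4 ug/mL
Compound 2 `OCC#CCSc1cnc2ccccc2c1[Se]CC#CCCl`: 2 ug/mL

Within the data shown here, in a functional assay on P388 cells (Mus musculus) for antiproliferative activity, with a stated time of 72 h (a higher number here means a weaker inhibitor, a lower number a stronger inhibitor), compound 1 gives 0.4 ug/mL, the lowest of the two numbers measured so far, while compound 2 gives 2 ug/mL. Among the measured compounds shown here, the one measured step, a 5.0-fold higher number from compound 1 to compound 2 (0.70 log units; beyond the scatter), came from placing 3-hydroxyprop-1-yn-1-yl in place of hydrogen on a saturated chain carbon bound to a sulfur. The unmeasured compound 3 `CSc1cnc2ccccc2c1SCC#CCO` differs from compound 1 in a different way: a group of 6 heavy atoms (4 carbon, 1 oxygen, 1 sulfur; no ring) in place of a group of 6 heavy atoms (4 carbon, 1 chlorine, 1 selenium; no ring), on an aromatic carbon. For the measured compounds named here, no measured step matches this exchange, so the step that produced compound 2 is the only guide, and it moved toward a higher number when an oxygen-bearing group entered. A step in that same direction, of uncertain size, is therefore expected for compound 3, a 3.8-fold higher number from compound 1 to compound 3 (0.57 log units; beyond the scatter), though it may not clear the scatter. Compound 3 is estimated at 1.5 ug/mL, within a range of 0.4 ug/mL to 6 ug/mL.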

Compound 3, concentration for 50% inhibition: 3.1 ug/mL
The estimate for compound 3 lay 2.1-fold (0.32 log units) below the measured number, and the stated range covers the measured number.
By their numbers in this assay, from the lowest: compound 1; then compounds 2 and 3 (each within the scatter of the next).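

The group on the aromatic carbon opposite the ring nitrogen matters in this assay: exchanging it gives a 7.8-fold higher number from compound 1 to compound 3 (0.89 log units; beyond the scatter), whereas the earlier step changed only the group on the other sulfur. The exchange keeps the heavy-atom count and the triple bond outside aromatic rings, so a higher number can arise even when those two counts stay the same, while the atoms differ and a hydrogen-bond donor and hydrogen-bond acceptors enter. No measurement here gives a reason for this shift.

Sulfur replaces selenium and oxygen replaces chlorine in one exchange, so the compounds shown leave open which of the two accounts for the step. A chain keeping selenium but ending in a hydroxyl group would help separate them, and an amine at the chain end or a longer chain remains an open question.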